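Ring Size of the Amine on the Side Chain

The compounds below may be only part of what the source reports. "The series", "measured", "known", "first", "only" and "open" are said of these compounds alone.

Compound 1 `COc1cc2c(Nc3ccc(C#N)cc3)ncnc2cc1OCCCN(C)Cc1ccccc1` reaches only the limit > 100000 nM in a functional assay on SH-SY5Y cells (Homo sapiens) for antiproliferative activity, read by MTT assay, with a stated time of 72 h; on this read-out higher numbers stand for weaker inhibition and lower numbers for stronger inhibition. Compound 2 `COc1cc2c(Nc3ccc(C#N)cc3)ncnc2cc1OCCCN1CCCC1` gives 8080 nM in this assay, the only number shown. Within the data shown here, the single measured step, an at least 12-fold lower number from compound 1 to compound 2 (1.09 log units; beyond the scatter), rests on (the limit of > 100000 nM in this assay, at which 1 of the 2 values shown sits), so its true size is not known. Compound 3 `COc1cc2c(Nc3ccc(C#N)cc3)ncnc2cc1OCCCN1CCCCC1` carries piperidin-1-yl in place of pyrrolidin-1-yl on a saturated chain carbon, three bonds along the chain from an oxygen on an aromatic ring. That earlier step also changed the amine, but from a very different group, so it bears on compound 3 only loosely. The expected step of a 1.2-fold lower number from compound 2 to compound 3 (0.06 log units; within the scatter) is within the scatter. Compound 3 is therefore estimated at 7000 nM, between 3000 nM and 20000 nM.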

Compound 3, half-maximal inhibitory concentration: 18800 nM
Compound 3: middle estimate off by 2.7-fold (0.43 log units), on the low side; low and high end bracket the measured number.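

In this assay, the size of the saturated ring on the amine now counts: piperidin-1-yl in place of pyrrolidin-1-yl brings a 2.3-fold higher number from compound 2 to compound 3 (0.37 log units; beyond the scatter), so the five-membered ring carries the lower number at this place. Piperidin-1-yl in place of benzyl(methyl)amino still brings an at least 5.3-fold lower number from compound 1 to compound 3 (0.72 log units; beyond the scatter). Compound 1 stands at a limit, so this step gives no true size: the limit of > 100000 nM in this assay, at which 1 of the 3 values shown sits.

Going by these compounds, whether azetidin-1-yl or azepan-1-yl would extend this ring-size difference remains open. So does the effect of morpholin-4-yl, with an oxygen in the ring, or of a longer chain.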